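Swapping an Amine on an Amide and Cell Toxicity

A few compounds are considered here, and "the series" means these few. Any claim that something is new, unique, unknown or untested is made for them only; others in the source may bear on it.

Compound 1 `CC(C)N(C(=O)CCNC(=O)c1ccc(S(C)(=O)=O)c([N+](=O)[O-])c1)C(C)C`, compound 2 `CC(C)N(C(=O)C1CCN(C(=O)c2ccc(S(C)(=O)=O)c([N+](=O)[O-])c2)CC1)C(C)C` and compound 3 `CS(=O)(=O)c1ccc(C(=O)NCCC(=O)N2CCc3ccccc3C2)cc1[N+](=O)[O-]` were tested in an ADME assay on HepG2 cells (Homo sapiens) for cytotoxicity, read by CellTiter-Glo and ATP content, with a stated time of 72 h; on this read-out higher numbers stand for an effect only at larger amounts of compound and lower numbers for an effect already at smaller amounts. In this assay compound 1 reaches only the assay limit of > 27000 nM. Compound 2 likewise gives only a limit, > 27000 nM. Compound 3 also stops at a limit, > 27000 nM. Going from compound 1 to compound 3 the change is 1,2,3,4-tetrahydroisoquinolin-2-yl in place of diisopropylamino on a carbonyl carbon, and the step is a step that the two limits leave unreadable from compound 1 to compound 3. How the core of compound 2 differs from that of compound 1 is not broken down here. Compound 4 `CS(=O)(=O)c1ccc(C(=O)N2CCC(C(=O)N3CCc4ccccc4C3)CC2)cc1[N+](=O)[O-]` carries the same kind of change against compound 2, (1,2,3,4-tetrahydroisoquinolin-2-yl in place of diisopropylamino on a carbonyl carbon), the carbonyl carbon now having a saturated ring carbon as its other neighbour rather than a saturated chain carbon. Because (the limit of > 27000 nM in this assay, at which 3 of the 3 values shown sit), compound 4 is expected to stay at that limit, with an expected step that the limit leaves unreadable from compound 2 to compound 4. The estimate for compound 4 is 30000 nM, expected to lie between 15000 nM and 80000 nM.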

Compound 4, half-maximal effective concentration: > 27000 nM
Compound 4 was reported as a limit; the forecaster's own chance of this, stated with the estimate: 85%; the middle value lies beyond the limit too.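

Compound 2 and compound 4 both stop at an assay limit, so no step can be read between them: the limit of > 27000 nM in this assay, at which 4 of the 4 values shown sit.

The compounds shown leave open whether swapping diisopropylamino for 1,2,3,4-tetrahydroisoquinolin-2-yl changes cell toxicity at all.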